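The compounds below may be only part of what the source reports. "The series", "measured", "known", "first", "only" and "open" are said of these compounds alone.

Measured compounds in an assay (Rattus norvegicus) for inhibition of Fatty-acid amide hydrolase 1 (Homo sapiens); a higher number here means a weaker inhibitor, a lower number a stronger inhibitor:
- compound 1 `COc1ccccc1-c1cnc(C(=O)CCCCCCc2ccccc2)o1` gives 400 nM
- compound 2 `NS(=O)(=O)c1ccccc1-c1cnc(C(=O)CCCCCCc2ccccc2)o1` gives 1500 nM

Compound 2 has the highest number of the two, with compound 1 giving the lower one. The change considered here leads to compound 3 `N#Cc1ccccc1-c1cnc(C(=O)CCCCCCc2ccccc2)o1`: cyano in place of sulfamoyl on an aromatic carbon. For the measured compounds named here, only one measured step touches this position: a 3.8-fold higher number from compound 1 to compound 2 (0.57 log units; beyond the scatter), which moved the number modestly. As the group that raised the number now leaves, compound 3 is expected to give a modestly lower number than compound 2, as estimated by a 2.5-fold lower number from compound 2 to compound 3 (0.40 log units; beyond the scatter). Compound 3 is therefore estimated at 600 nM, with a range from 200 nM to 2000 nM.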

Compound 3, inhibition constant: 130 nM
Compound 3: middle estimate off by 4.6-fold (0.66 log units), on the high side; measured number below the stated range.
By their numbers in this assay, from the lowest: compound 3; then compound 1; then compound 2.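

In this assay the swap of sulfamoyl for cyano gives a 12-fold lower number from compound 2 to compound 3 (1.06 log units; beyond the scatter) as a large step, so removing sulfamoyl does more than return the number to the methoxy level. Cyano also improves on methoxy at this aromatic carbon, with a 3.1-fold lower number from compound 1 to compound 3 (0.49 log units; beyond the scatter) beyond the scatter, which shows that this position can yield a stronger inhibitor than compound 1. No evidence at hand accounts for this order among the three groups.

From the compounds shown here alone, whether this gain is particular to cyano remains open. The compounds shown do not tell how a fluorine, a methyl, an amine or a carboxylic acid would behave at this position.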